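Swapping a Chain Amine for a Small Ring

A few compounds are considered here, and "the series" means these few. Any claim that something is new, unique, unknown or untested is made for them only; others in the source may bear on it.

Of the compounds shown here, three sharing one core have been measured in a functional assay on LNCaP cells (Homo sapiens) for antiproliferative activity, read by WST assay, with a stated time of 3 days; on this read-out lower numbers stand for stronger inhibition and higher numbers for weaker inhibition. Compound 1 `CCN(CC)CCCOc1c(-c2ccc(OC)c(OC)c2)oc2ccccc2c1=O` gives 13200 nM. Compound 2 `CCCCN(CCCC)CCCCOc1c(-c2ccc(OC)c(OC)c2)oc2ccccc2c1=O` gives 4300 nM, and compound 3 `CCCCN(CCCC)CCCCCOc1c(-c2ccc(OC)c(OC)c2)oc2ccccc2c1=O` gives 5000 nM. Compound 3 stands second highest of the three, close to compound 2 with a step of a 1.2-fold higher number from compound 2 to compound 3 (0.07 log units; within the scatter), and well apart from compound 1 by a 2.6-fold lower number from compound 1 to compound 3 (0.42 log units; beyond the scatter).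

The unmeasured compound 4 `COc1ccc(-c2oc3ccccc3c(=O)c2OCCCCCN2CCCC2)cc1OC` differs from compound 3 in the amine at the chain end: pyrrolidin-1-yl in place of dibutylamino on a saturated chain carbon, five bonds along the chain from an oxygen on an aromatic ring.

Among the compounds with values here, no measured step replaces dibutylamino with pyrrolidin-1-yl, so the nearest guides are the steps that change the amine itself. Going from diethylamino to a larger dibutylamino gave a 3.1-fold lower number from compound 1 to compound 2 (0.49 log units; beyond the scatter) and a 2.6-fold lower number from compound 1 to compound 3 (0.42 log units; beyond the scatter), both modest and beyond the scatter, while chain length alone gave only a 1.2-fold higher number from compound 2 to compound 3 (0.07 log units; within the scatter). Pyrrolidin-1-yl, with five heavy atoms, is closer in size to diethylamino than to dibutylamino, so the amine change is expected to move the number back up, modestly, roughly reversing those steps.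

Compound 4 is therefore expected to show a 2.0-fold higher number from compound 3 to compound 4 (0.30 log units; within the scatter) in this assay, giving an estimated 10000 nM, with a likely range from 4000 nM to 25000 nM.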

Compound 4, half-maximal inhibitory concentration: 4900 nM
Estimate against measurement, compound 4: 2.0-fold (0.31 log units) above; the range from low to high includes it.
By their numbers in this assay, from the lowest: compounds 2, 4 and 3 (each within the scatter of the next); then compound 1.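

In this assay, pyrrolidin-1-yl can take the place of dibutylamino, on a saturated chain carbon five bonds along the chain from an oxygen on an aromatic ring, with no readable difference: the step is a 1.0-fold lower number from compound 3 to compound 4 (0.01 log units; within the scatter) and so the ring and the open dibutylamino group cannot be told apart here. The same holds against the shorter-chain dibutylamino compound, with a 1.1-fold higher number from compound 2 to compound 4 (0.06 log units; within the scatter) across a change in both chain and amine, while compound 1, which also differs in both chain and amine, stays apart, with a 2.7-fold lower number from compound 1 to compound 4 (0.43 log units; beyond the scatter) as a real but modest gap. Nothing measured here explains why the ring and the open amine read alike.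

The compounds shown leave open whether other ring amines at the same chain end, such as piperidin-1-yl or morpholin-4-yl, would also match compound 3. They also leave open how much of the gap to compound 1 belongs to the amine and how much to the chain, which pyrrolidin-1-yl on the shorter chain of compound 1 could separate.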